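Dichlorophenyl hydrazone variants on a shared core

A few compounds are considered here, and "the series" means these few. Any claim that something is new, unique, unknown or untested is made for them only; others in the source may bear on it.

Compound 1 `CN(C)CCn1cnnc1-c1cc(Oc2ccc(NC(=O)N/N=C/c3ccc(Cl)cc3Cl)cc2F)ccn1`: 750 nM
Compound 2 `COc1ccc(OC)c(/C=N/NC(=O)Nc2ccc(Oc3ccnc(-c4nncn4CCN(C)C)c3)c(F)c2)c1`: 1510 nM
Compound 3 `CN(C)CCn1cnnc1-c1cc(Oc2ccc(NC(=O)N/N=C/c3ccccc3)cc2F)ccn1`: 2730 nM

Three compounds share a core and differ only in the aryl group on the carbon with a double bond to nitrogen. In a functional assay on MKN-45 cells (Homo sapiens) for cytotoxicity, read by MTT assay, with a stated time of 72 h (on this read-out lower numbers stand for stronger inhibition and higher numbers for weaker inhibition), compound 1 gives 750 nM, compound 2 gives 1510 nM and compound 3 gives 2730 nM. Compound 3 has the highest number of the three; the step of a 1.8-fold higher number from compound 2 to compound 3 (0.26 log units; within the scatter) is within the scatter, while the step of a 3.6-fold higher number from compound 1 to compound 3 (0.56 log units; beyond the scatter) is beyond it.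

Compound 4 `CN(C)CCn1cnnc1-c1cc(Oc2ccc(NC(=O)N/N=C/c3cccc(Cl)c3Cl)cc2F)ccn1` is the next step from compound 3: 2,3-dichlorophenyl in place of phenyl on a carbon with a double bond to nitrogen. Among the compounds with values here, the closest precedent is the step of a 3.6-fold higher number from compound 1 to compound 3 (0.56 log units; beyond the scatter), which shows that removing two chlorines from this ring raised the number modestly; compound 4 instead brings a dichlorophenyl, though with a different substitution pattern from compound 1, and no measured pair covers that pattern. Compound 4 is therefore expected to move back toward compound 1, an expected step of a 2.3-fold lower number from compound 3 to compound 4 (0.36 log units; beyond the scatter) in this assay. Compound 4 is estimated at 1200 nM, with a range from 500 nM to 2800 nM.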

Compound 4, half-maximal inhibitory concentration: 51 nM
Compound 4: middle estimate off by 24-fold (1.37 log units), on the high side, and the stated range ends above it.
By their numbers in this assay, from the lowest: compound 4; then compounds 1, 2 and 3 (each within the scatter of the next, the first and the last beyond it).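

Within the data shown here, at this place on the shared core, the aryl group can shift the number far more than the earlier compounds showed in this assay (the largest step among them was modest), as the 2,3-dichlorophenyl group gives steps of (a 54-fold lower number from compound 3 to compound 4 (1.73 log units; beyond the scatter)) and (a 30-fold lower number from compound 2 to compound 4 (1.47 log units; beyond the scatter)). The arrangement of the chlorines matters as well as their presence, since exchanging 2,4-dichlorophenyl for 2,3-dichlorophenyl alone gives a large step (a 15-fold lower number from compound 1 to compound 4 (1.17 log units; beyond the scatter)). Nothing available here explains this difference.

The compounds shown leave open whether one chlorine alone would give a similarly low number, or whether both are needed. They also leave open whether the gain is specific to chlorine, or would carry over to a 2,3-dibromophenyl or 2,3-dimethylphenyl group on the same carbon.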